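The compounds below may be only part of what the source reports. "The series", "measured", "known", "first", "only" and "open" are said of these compounds alone.

Measured in a functional assay on MDA-MB-231 cells (Homo sapiens) for cytotoxicity, read by MTT assay, with a stated time of 48 h; on this read-out higher numbers stand for weaker inhibition and lower numbers for stronger inhibition:

- Compound 1 `CC(C)=CCC/C(C)=C/CC/C(C)=C/CSc1ccccc1C(=O)N[C@@H](C)C(=O)OCC#CCOc1no[n+]([O-])c1S(=O)(=O)c1ccccc1`: 1010 nM
- Compound 2 `CC(C)=CCC/C(C)=C/CC/C(C)=C/CSc1ccccc1C(=O)N[C@@H](C)C(=O)OCCCCOc1no[n+]([O-])c1S(=O)(=O)c1ccccc1`: > 50000 nM, a limit of the assay and not a number
- Compound 3 `CC(C)=CCC/C(C)=C/CC/C(C)=C/CSc1ccccc1C(=O)N[C@@H](C)C(=O)OCCOCCOc1no[n+]([O-])c1S(=O)(=O)c1ccccc1`: 4210 nM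

Only two of these results are numbers. Compound 3, at 4210 nM, holds the higher of the two. Compound 1, at 1010 nM, lies lower, and that gap goes beyond the usual scatter. Compound 2 gave only a limit, so it cannot be placed exactly against the others.

Compound 4 `CC(C)=CCC/C(C)=C/CC/C(C)=C/CSc1ccccc1C(=O)NCC(=O)OCCOCCOc1no[n+]([O-])c1S(=O)(=O)c1ccccc1` keeps the rest of compound 3 and changes in one place: hydrogen in place of methyl on a saturated chain carbon bound to an amide-type nitrogen and a carbonyl carbon. All three measured compounds carry that methyl, so none of them shows directly what its loss does in this assay. Going by the values given here, with only this one small change and no precedent for a direction, the result is expected to stay close to compound 3 at 4210 nM. The expected change is a 1.1-fold lower number from compound 3 to compound 4 (0.02 log units; within the scatter), which would not be a clear shift in either direction. The estimate for compound 4 is 4000 nM, with an expected range from 1500 nM to 12000 nM.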

Compound 4, half-maximal inhibitory concentration: 2410 nM
Compound 4: middle estimate off by 1.7-fold (0.22 log units), on the high side, and the stated range covers the measured number.
By their numbers in this assay, from the lowest: compound 1; then compounds 4 and 3 (each within the scatter of the next). At a limit, above all of these: compound 2.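

In this assay the exchange of methyl for hydrogen on a saturated chain carbon bound to an amide-type nitrogen and a carbonyl carbon gives a 1.7-fold lower number from compound 3 to compound 4 (0.24 log units; within the scatter) and so produces no clear shift at this position. Going by these compounds alone, all the earlier compounds carried this methyl, so only this pair shows that, with the rest of compound 3 kept, the read-out cannot be told apart with or without the methyl. No measurement given here offers a reason for this outcome.

Going by these compounds, the step rests on a single pair, so it stays open whether hydrogen in place of methyl would act the same way with the chains that link the ester to the shared core in compound 1 and compound 2. Also open, on these data alone, is what the same carbon would do if it carried something other than hydrogen or this methyl, such as an ethyl, a benzyl or a side chain ending in a carboxylic acid or an amine, or if the methyl stood in the opposite configuration.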